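Swapping the Anilino Linker for a Phenoxy Linker

A few compounds are considered here, and "the series" means these few. Any claim that something is new, unique, unknown or untested is made for them only; others in the source may bear on it.

Of the compounds shown here, two have been measured so far in a functional assay on PC-3 cells (Homo sapiens) for inhibition, read by WST assay, tested at 100 uM; a higher number here means a stronger effect of the compound at the concentration tested, a lower number a weaker effect. Compound 1, `O=C(CCCNC(=O)c1cc(C(F)(F)F)cc(C(F)(F)F)c1)Nc1ccc(Cl)cc1`, gives 12%. Compound 2, `O=C(NCCCNc1ccc(Cl)cc1)c1cc(C(F)(F)F)cc(C(F)(F)F)c1`, gives 11% in this assay. Compound 2 holds the lowest of the two numbers, but the step of a number 1 percentage points lower from compound 1 to compound 2 (within the scatter) is within the scatter, so the two compounds cannot be told apart on these data.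

Compound 3, `O=C(NCCCOc1ccc(Cl)cc1)c1cc(C(F)(F)F)cc(C(F)(F)F)c1`, differs from compound 2 at one place: 4-chlorophenoxy in place of (4-chlorophenyl)amino on a saturated chain carbon, three bonds along the chain from an amide-type nitrogen. Among the compounds with values here, the only measured step, a number 1 percentage points lower from compound 1 to compound 2 (within the scatter), altered the group at the same place on the chain and produced no change beyond the scatter. Within the data shown here, that step is the sole guide, and it gives no reason to expect a noticeable move.

Compound 3 is therefore expected to show a step of about a number 1 percentage points lower from compound 2 to compound 3 (within the scatter) in this assay. The estimate for compound 3 is 10%, with a range from 0% to 25%.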

Compound 3, a percentage reported as inhibition, at one concentration (the size of the read-out at that concentration, not a potency): 38%
Compound 3: the middle estimate sits 28 percentage points below what was measured, and the stated range ends below it.
By their numbers in this assay, from the lowest: compounds 2 and 1 (each within the scatter of the next); then compound 3.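

In this assay this position on a saturated chain carbon, three bonds along the chain from an amide-type nitrogen, turns out to respond to what sits there, giving a number 27 percentage points higher from compound 2 to compound 3 (beyond the scatter) when 4-chlorophenoxy replaces (4-chlorophenyl)amino. That swap leaves the chlorinated ring and the heavy-atom count unchanged, exchanges the linking nitrogen for oxygen, and removes the hydrogen-bond donor. The comparison with the carbamoyl-linked compound tells the same story, with a number 26 percentage points higher from compound 1 to compound 3 (beyond the scatter), but no measurement here accounts for the rise.

The compounds shown leave open whether the rise follows the loss of the hydrogen on that nitrogen or the presence of oxygen itself, which a thioether sulfur, a methylene or an N-methyl amine at this link could separate. As far as these compounds go, whether it survives a longer chain also remains open.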